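Alkyne-linked series: methoxy to trifluoromethyl swap

This account rests on a few compounds, and the source may have more. Where it says the series, first, only, none or still open, it means among the compounds named here.

Three compounds carry numbers in an assay on CHO cells for displacement of a labelled ligand from prostaglandin D2 receptor 2 (Homo sapiens), read by scintillation counting; on this read-out higher numbers stand for weaker inhibition and lower numbers for stronger inhibition. Compound 1 `COc1ccccc1C#Cc1cc(Cl)ccc1OCC(=O)O` gives 190 nM, the highest of the three. Compound 2 `Cc1ncccc1C#Cc1cc(Cl)ccc1OCC(=O)O` gives 143 nM in this assay, within the scatter of compound 1. Compound 3 `Cc1ccc(S(=O)(=O)Cc2ccccc2)cc1C#Cc1cc(Cl)ccc1OCC(=O)O` gives 5 nM in this assay, a far lower number, beyond the scatter relative to compound 1. Compound 4 `O=C(O)COc1ccc(Cl)cc1C#Cc1ccccc1C(F)(F)F` remains unmeasured. It differs from compound 1 by trifluoromethyl in place of methoxy on an aromatic carbon, on an aromatic carbon of a six-membered aromatic ring of carbon only, ortho to a large group. Among the compounds with values here, no measured pair shows this change, so its size is unknown. For this assay the expected step is a 1.3-fold lower number from compound 1 to compound 4 (0.10 log units; within the scatter), not beyond the scatter. Compound 4 is estimated at 150 nM, ranging from 50 nM to 450 nM.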

Compound 4, inhibition constant: 24 nM
Compound 4: the middle estimate sits 6.3-fold (0.80 log units) above what was measured, and the stated range ends above it.
By their numbers in this assay, from the lowest: compound 3; then compound 4; then compounds 2 and 1 (each within the scatter of the next).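

In this assay, trifluoromethyl in place of methoxy on an aromatic carbon, ortho to a large group, gives a 7.9-fold lower number from compound 1 to compound 4 (0.90 log units; beyond the scatter). Within the data shown here, this single-place step shows that the number responds to the group at this position, which the earlier compounds, differing in more than one place, could not show. Nothing available accounts for the size of this step.

From the compounds shown here alone, whether a nitrile or an ethoxy group on the same carbon would track trifluoromethyl or methoxy remains open. Also open, going by these compounds, is whether the step would carry over to the core of compound 3.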